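This account rests on a few compounds, and the source may have more. Where it says the series, first, only, none or still open, it means among the compounds named here.

Working notes on the series, read in a functional assay on MGC-803 cells (Homo sapiens) for inhibition, read by MTT assay, with a stated time of 72 h; a higher number here means a weaker inhibitor, a lower number a stronger inhibitor. Among the measured compounds shown here, compound 1 `C#CCSc1nc(Nc2ccc(C)cc2)c2ccncc2n1` gives 8090 nM, the second highest of the three numbers so far. Compound 2 `C#CCSc1nc(Nc2ccc(Cl)cc2)c2ccncc2n1` gives 16400 nM, and compound 3 `C#CCSc1nc(Nc2cccc(Cl)c2)c2ccncc2n1` gives 2190 nM. Compound 4 `C#CCSc1nc(Nc2ccc(Br)cc2)c2ccncc2n1` has no number yet. Its difference from compound 1 is bromo in place of methyl on an aromatic carbon, para to a large group.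

For the measured compounds named here, the nearest precedent is a 2.0-fold higher number from compound 1 to compound 2 (0.31 log units; beyond the scatter), where chloro replaces methyl and 4-chlorophenyl replaces 4-methylphenyl. That step is modest and points to a higher number. The larger steps of a 3.7-fold lower number from compound 1 to compound 3 (0.57 log units; beyond the scatter) and a 7.5-fold lower number from compound 2 to compound 3 (0.87 log units; beyond the scatter) both bring in 3-chlorophenyl, which compound 4 lacks, so they bear on it only weakly. A modest step towards a higher number is therefore expected, no larger than the chloro step and possibly within the scatter. The expected change is a 1.5-fold higher number from compound 1 to compound 4 (0.17 log units; within the scatter). Compound 4 is estimated at 12000 nM, with an expected range of 5000 nM to 28000 nM.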

Compound 4, half-maximal inhibitory concentration: 26000 nM
The estimate for compound 4 lay 2.2-fold (0.34 log units) below the measured number, within the range that was stated.
By their numbers in this assay, from the lowest: compound 3; then compound 1; then compounds 2 and 4 (each within the scatter of the next).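

In this assay, bromo in place of methyl on an aromatic carbon, para to a large group, gives a 3.2-fold higher number from compound 1 to compound 4 (0.51 log units; beyond the scatter), while bromo in place of chloro at the same place gives a 1.6-fold higher number from compound 2 to compound 4 (0.20 log units; within the scatter), so chloro and bromo are not separated here and both stand on the higher side of methyl. The step of a 12-fold higher number from compound 3 to compound 4 (1.07 log units; beyond the scatter) is the largest in the series and widens the gap between 3-chlorophenyl and the 4-substituted phenyl groups shown. No measurement shown here bears on the reason for these differences.

Still open, on these data alone, is whether a methoxy group, an amine or a carboxylic acid on the same aromatic carbon would follow methyl, the two halogens or neither. Also open, as far as these compounds go, is whether the lower number of 3-chlorophenyl extends to any other group on that ring.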